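Amide-linked isothiocyanate chains on a shared core

The compounds below may be only part of what the source reports. "The series", "measured", "known", "first", "only" and "open" are said of these compounds alone.

Measured compounds:
Compound 1, `CN(C)C(=O)c1cc2cnc(Nc3ccc(S(=O)(=O)NCCCCN=C=S)cc3)nc2n1C1CCCC1`: in a functional assay on NCI-H1299 cells (Homo sapiens) for inhibition, read by CCK-8 assay, with a stated time of 72 h, tested at 10 uM (a lower number here means a weaker effect, a higher number a stronger effect of the compound at the concentration tested), compound 1 gives 72.7%.
Compound 2, `CN(C)C(=O)c1cc2cnc(Nc3ccc(C(=O)NCCCN=C=S)cc3)nc2n1C1CCCC1`: compound 2 gives 91.2%.
Compound 3, `CN(C)C(=O)c1cc2cnc(Nc3ccc(C(=O)NCCCCCN=C=S)cc3)nc2n1C1CCCC1`: compound 3 gives 76.5%.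

Compound 3 stands second of the three numbers. The step of a number 3.8 percentage points higher from compound 1 to compound 3 (within the scatter) means compounds 1 and 3 cannot be ordered, whereas the step of a number 14.7 percentage points lower from compound 2 to compound 3 (beyond the scatter) lies beyond the scatter. Compound 4, `CN(C)C(=O)c1cc2cnc(Nc3ccc(NC(=O)CCCN=C=S)cc3)nc2n1C1CCCC1`, is not yet measured. It differs from compound 3 by a group of 9 heavy atoms (5 carbon, 2 nitrogen, 1 oxygen, 1 sulfur; no ring) in place of a group of 11 heavy atoms (7 carbon, 2 nitrogen, 1 oxygen, 1 sulfur; no ring), on an aromatic carbon. For the measured compounds named here, two measured steps bear on this. A group of 9 heavy atoms in place of a group of 11 heavy atoms on an aromatic carbon gave a number 18.5 percentage points higher from compound 1 to compound 2 (beyond the scatter), and lengthening the chain gave a number 14.7 percentage points lower from compound 2 to compound 3 (beyond the scatter). A modest rise is therefore expected for compound 4, about a number 8.5 percentage points higher from compound 3 to compound 4 (within the scatter). Compound 4 is estimated at 85%, within 70% to 95%.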

Compound 4, a percentage reported as inhibition, at one concentration (the size of the read-out at that concentration, not a potency): 78.8%
The estimate for compound 4 lay 6.2 percentage points above the measured number, within the range that was stated.
By their numbers in this assay, from the lowest: compounds 1, 3 and 4 (each within the scatter of the next); then compound 2.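

In this assay, the two groups in the step of a number 12.4 percentage points lower from compound 2 to compound 4 (beyond the scatter) have identical atom counts and differ only in the order of the carbonyl and the amide nitrogen, so this position distinguishes the direction of the amide link. Compound 4 still cannot be ordered against the two lower compounds, with a number 2.3 percentage points higher from compound 3 to compound 4 (within the scatter) and a number 6.1 percentage points higher from compound 1 to compound 4 (within the scatter) as the steps. Nothing available explains the effect of the reversed link. Open questions are whether a longer chain on the reversed amide would change the number, and how an amine in place of the isothiocyanate would read.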